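Ring-nitrogen aryl swaps in the phenylsuccinimide acetamide series

The source may report more compounds than this note shows. Statements on the series, on what has been measured and on what is new or still open speak of the compounds shown alone.

Compound 3 `CC1(c2ccccc2)CC(=O)N(CC(=O)N2CCN(c3ncccn3)CC2)C1=O` stands at 100 mg/kg in a functional assay on the whole organism (strain CD-1) with Mus musculus as the target, with a stated time of 2 h; on this read-out higher numbers stand for an effect only at larger amounts of compound and lower numbers for an effect already at smaller amounts. Compound 2 `CC1(c2ccccc2)CC(=O)N(CC(=O)N2CCN(c3ccccc3Cl)CC2)C1=O` gives 100 mg/kg, so the step of no change at the digits printed from compound 2 to compound 3 (within the scatter) leaves the read-out where it was. Among the measured compounds shown here, compound 1 `Cc1cccc(N2CCN(C(=O)CN3C(=O)CC(C)(c4ccccc4)C3=O)CC2)c1` is recorded as "not active" (no number reported); no number came with it, and no step from it to any other compound has been computed, so it only shows that the series contains an entry with no measurable effect in this assay.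

Compound 4 `CC1(c2ccccc2)CC(=O)N(CC(=O)N2CCN(c3cccc(C(F)(F)F)c3)CC2)C1=O` differs from compound 3 by 3-(trifluoromethyl)phenyl in place of pyrimidin-2-yl on an amine nitrogen in a ring. For the measured compounds named here, the one measured step that bears on a change of the group on the ring nitrogen is no change at the digits printed from compound 2 to compound 3 (within the scatter), which was flat; nothing else exchanges that group between two numbered entries. The expectation for compound 4 is therefore a step of no change at the digits printed from compound 3 to compound 4 (within the scatter) of no size beyond the scatter, with the note that the outcome of compound 1 leaves open a result without any number.

Compound 4 is expected at 100 mg/kg, within 50 mg/kg to 300 mg/kg.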

Compound 4, minimum effective dose: "not active" (no number reported)
The entry for compound 4 holds no number, so the estimate cannot be set against anything.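

Among the compounds shown here, with compound 4 recorded as "not active" (no number reported), no step from compound 3 to compound 4 can be read. The compounds shown leave open how the group on the ring nitrogen relates to activity, with compound 1 and compound 4 lacking numbers. No available evidence bears on this result.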